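Triazene Nitrogen Swap: Thiophenyl Out, Butyl In

The source may hold more compounds than are shown below. What is called first, only, known or untested is meant among the compounds shown, and "the series" means these compounds.

Among the measured compounds shown here, compound 1 `CN(/N=N/c1ccc(C(N)=O)cc1)c1cccs1` is one of three compounds measured in a functional assay on L1210 cells (Mus musculus) for antiproliferative activity (on this read-out lower numbers stand for lower potency and higher numbers for higher potency (the scale is a negative logarithm)), where compound 1 gives 2.9. Two others frame it: compound 2 `COC(=O)c1cccc(/N=N/N(C)C)c1` gives 3.42 in this assay, a number higher than that of compound 1 by more than the usual scatter, and compound 3 `CN(C)/N=N/c1ccccc1C(=O)/N=N/C(=O)CC#N` gives 2.63, a number that lies within the scatter of compound 1 and so cannot be told apart from it. Compound 1 therefore holds the second highest of the three numbers, with compound 2 clearly above it and compound 3 level with it.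

Compound 4 `CCCCN(C)/N=N/c1ccc(C(N)=O)cc1` has not yet been measured. It differs from compound 1 in one place: butyl in place of thiophen-2-yl on an amine nitrogen. For the measured compounds named here, no pair of measured compounds that differ in only one place is available, so this step has no direct precedent. Going by the values given here, the only guide is that compound 2, which carries two methyl groups on the amine nitrogen, reaches 3.42. On that basis compound 4 is expected to come out higher than compound 1, with an estimated step of a number 0.60 log units higher from compound 1 to compound 4 (beyond the scatter) in this assay. The estimate for compound 4 in this assay is 3.5, with a range from 3 to 4.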

Compound 4, logarithm of the reciprocal of the active concentration, log(1/C): 3.47
Estimate against measurement, compound 4: 0.03 log units above; measured number inside the range.
By their numbers in this assay, from the lowest: compounds 3 and 1 (each within the scatter of the next); then compounds 2 and 4 (each within the scatter of the next).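

Among the compounds shown here, this step gives the first direct reading of the group on this amine nitrogen. In this assay, with the rest of the structure unchanged, butyl in place of thiophen-2-yl gives a number 0.57 log units higher from compound 1 to compound 4 (beyond the scatter), so the group at this position does affect the number, and the aromatic ring is not needed to keep activity in this pair. Nothing shown explains the rise, and a single pair cannot separate the loss of the ring from the loss of the sulfur.

A cyclohexyl or phenyl group on the same nitrogen could help separate those two changes, while an ethyl group or a longer chain such as hexyl could show whether chain length matters. As far as these compounds go, whether butyl has the same effect on a different core also remains open.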